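Dropping the substituents from compound 3

A few compounds are considered here, and "the series" means these few. Any claim that something is new, unique, unknown or untested is made for them only; others in the source may bear on it.

Among the measured compounds shown here, compound 3 `CN(C)C(=O)c1cc2cnc(Nc3ccc(NC(=O)C4(C(=O)Nc5ccc(Cl)c(C(F)(F)F)c5)CC4)cc3)nc2n1C1CCCC1` gives 55.8% in a functional assay on T47D cells (Homo sapiens) for inhibition, read by CCK-8 assay, with a stated time of 72 h, tested at 10 uM (a lower number here means less inhibition of growth, a higher number more inhibition of growth at the concentration tested), and stands lowest of the three numbers so far. Compound 1 `Cc1cccc(NC(=O)C2(C(=O)Nc3ccc(Nc4ncc5cc(C(=O)N(C)C)n(C6CCCC6)c5n4)cc3)CC2)c1` gives 95.3% and compound 2 `CN(C)C(=O)c1cc2cnc(Nc3ccc(NC(=O)C4(C(=O)Nc5ccc(Br)cc5)CC4)cc3)nc2n1C1CCCC1` gives 94.3% and these two lie within the scatter of each other. The unmeasured compound 4 `CN(C)C(=O)c1cc2cnc(Nc3ccc(NC(=O)C4(C(=O)Nc5ccccc5)CC4)cc3)nc2n1C1CCCC1` differs from compound 3 at one place phenyl in place of 4-chloro-3-(trifluoromethyl)phenyl on an amide-type nitrogen with phenyl in place of 4-chloro-3-(trifluoromethyl)phenyl on an amide-type nitrogen. For the measured compounds named here, two measured steps bear on this change: a number 39.5 percentage points lower from compound 1 to compound 3 (beyond the scatter) and a number 38.5 percentage points lower from compound 2 to compound 3 (beyond the scatter) both arrive at the group that compound 4 gives up, and both are large. Going by the values given here, no measured compound carries plain phenyl at this nitrogen, so a large upward step is expected, but it is set somewhat smaller than those two. The expected step is a number 32.2 percentage points higher from compound 3 to compound 4 (beyond the scatter) and it remains an estimate. In this assay compound 4 is estimated at 88% within a range from 68% to 98% as the expected outcome.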

Compound 4, percent growth inhibition at one concentration: 93.9%
Beside the measured number, compound 4's estimate is 5.9 percentage points below it, and the stated range covers the measured number.
By their numbers in this assay, from the lowest: compound 3; then compounds 4, 2 and 1 (each within the scatter of the next).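

In this assay replacing 4-chloro-3-(trifluoromethyl)phenyl with plain phenyl gives a number 38.1 percentage points higher from compound 3 to compound 4 (beyond the scatter). Compound 4 thus shows that no substituent on this ring is needed to reach the level of compounds 1 and 2. Hydrogen in place of bromo gives a number 0.4 percentage points lower from compound 2 to compound 4 (within the scatter) and hydrogen in place of methyl gives a number 1.4 percentage points lower from compound 1 to compound 4 (within the scatter) so neither of these two substituents can be told apart from hydrogen in this read-out. Among the four compounds the low number belongs to compound 3 alone, which ties it to the 4-chloro-3-(trifluoromethyl)phenyl group and not to substitution of the ring as such, and nothing on hand explains the difference.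

As far as these compounds go, whether chloro or trifluoromethyl alone would lower the number remains open. Also open, from the compounds shown here alone, is how an amine or a carboxylic acid on this ring would read.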